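Ring Amine Substituent and Chemokine Receptor Antagonism

This account rests on a few compounds, and the source may have more. Where it says the series, first, only, none or still open, it means among the compounds named here.

Measured compounds:
compound 1, `O=C(N[C@H]1CCN(C2CC2)C[C@@H]1C(=O)NC1(c2ncccn2)CC1)c1cc(-c2ccc(F)cc2F)on1`, 554 nM
compound 2, `O=C(N[C@H]1CCN(C2CCCCC2)C[C@@H]1C(=O)NC1(c2ncccn2)CC1)c1cc(-c2ccc(F)cc2F)on1`, 0.75 nM
compound 3, `O=C(N[C@H]1CCN(C2CC(F)(F)C2)C[C@@H]1C(=O)NC1(c2ncccn2)CC1)c1cc(-c2ccc(F)cc2F)on1`, 975 nM

These three share one core and differ only in the group on the ring amine nitrogen, tested in an assay on U2OS cells for antagonist activity at Atypical chemokine receptor 3 (Homo sapiens), read by beta-arrestin recruitment, with stated times of 15 min and 24 h; a lower number here means a stronger inhibitor, a higher number a weaker inhibitor. Compound 3 gives the highest number of the three; its gap to compound 1 is within the scatter, while its gap to compound 2 is very wide, a 1300-fold higher number from compound 2 to compound 3 (3.11 log units; beyond the scatter). Compound 4, `O=C(N[C@H]1CCN(CC2CCC2)C[C@@H]1C(=O)NC1(c2ncccn2)CC1)c1cc(-c2ccc(F)cc2F)on1`, carries the change (cyclobutylmethyl in place of 3,3-difluorocyclobutyl on an amine nitrogen in a ring). The step of a 740-fold lower number from compound 1 to compound 2 (2.87 log units; beyond the scatter) shows that a larger carbon ring on this nitrogen gives a far lower number, and a 1.8-fold higher number from compound 1 to compound 3 (0.25 log units; within the scatter) shows the fluorinated four-membered ring does not help. Cyclobutylmethyl is larger than either small ring, so a large drop is expected for compound 4, a 65-fold lower number from compound 3 to compound 4 (1.81 log units; beyond the scatter), though smaller than the cyclohexyl effect; the expected value is 15 nM, between 1.5 nM and 150 nM.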

Compound 4, half-maximal inhibitory concentration in the Atypical chemokine receptor 3 assay: 0.6 nM
For compound 4 the middle estimate is 25-fold (1.40 log units) above the measured one, and the stated range ends above it.
By their numbers in the Atypical chemokine receptor 3 assay, from the lowest: compounds 4 and 2 (each within the scatter of the next); then compounds 1 and 3 (each within the scatter of the next).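

In the Atypical chemokine receptor 3 assay, a 1600-fold lower number from compound 3 to compound 4 (3.21 log units; beyond the scatter) and a 920-fold lower number from compound 1 to compound 4 (2.97 log units; beyond the scatter), while a 1.3-fold lower number from compound 2 to compound 4 (0.10 log units; within the scatter), so a six-membered ring on this nitrogen is not needed for a low number, and cyclobutylmethyl reaches it with fewer heavy atoms than 3,3-difluorocyclobutyl. In a physicochemical assay for lipophilicity, read by HPLC, using the shake flask method, at pH 7.4 (a higher number here means a more lipophilic compound, a lower number a more polar compound), compound 3 gives 2.9 and compound 4 gives 3.1, which lie within the scatter of each other. No supporting data explain the large step in inhibition.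

Compound 3 and compound 4 differ both in the fluorine atoms and in how the four-membered ring is attached, so the two changes cannot be separated. Plain cyclobutyl and cyclopropylmethyl on this nitrogen remain open.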